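Replacing naphthalen-1-yl with 2,6-dimethylphenyl in compound 3

The source may hold more compounds than are shown below. What is called first, only, known or untested is meant among the compounds shown, and "the series" means these compounds.

Of the compounds shown here, three sharing one core have been tested in a functional assay on MCF7 cells (Homo sapiens) for cytotoxicity, read by MTT assay, with a stated time of 24 h; on this read-out lower numbers stand for stronger inhibition and higher numbers for weaker inhibition. Compound 1 `CCNc1cc(-c2ccc(NC(=O)Nc3ccc(C)cc3)cc2C)ccn1` gives 9210 nM, compound 2 `CCNc1cc(-c2ccc(NC(=O)Nc3ccc(C(F)(F)F)cc3)cc2C)ccn1` gives 6870 nM, and compound 3 `CCNc1cc(-c2ccc(NC(=O)Nc3cccc4ccccc34)cc2C)ccn1` gives 15500 nM. On these numbers, compound 3 stands clearly apart from compound 2 but cannot be told apart from compound 1.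

Compound 4 `CCNc1cc(-c2ccc(NC(=O)Nc3c(C)cccc3C)cc2C)ccn1` keeps the core and carries 2,6-dimethylphenyl in place of naphthalen-1-yl on an amide-type nitrogen. Among the compounds with values here, no tested compound carries 2,6-dimethylphenyl, so the evidence is indirect. Two measured steps bring naphthalen-1-yl onto that same nitrogen: the data show a 1.7-fold higher number from compound 1 to compound 3 (0.23 log units; within the scatter) and a 2.3-fold higher number from compound 2 to compound 3 (0.35 log units; beyond the scatter). Removing naphthalen-1-yl might therefore run the opposite way, by a similar modest size. A third step, a 1.3-fold lower number from compound 1 to compound 2 (0.13 log units; within the scatter), suggests that the numbers stay close when the group changes among compounds without naphthalen-1-yl. Three compounds are a thin basis, however, and a new group could behave differently.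

The expected result in this assay is a small move towards a lower number, and the estimate is a 1.6-fold lower number from compound 3 to compound 4 (0.19 log units; within the scatter), which would not stand clear of the scatter. Compound 4 is expected at about 10000 nM, with an estimated range of 5000 nM to 20000 nM.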

Compound 4, half-maximal inhibitory concentration: 7920 nM
For compound 4 the middle estimate is 1.3-fold (0.10 log units) above the measured one; the measured number falls inside the stated range.
By their numbers in this assay, from the lowest: compounds 2, 4, 1 and 3 (each within the scatter of the next, the first and the last beyond it).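

In this assay, swapping the two aromatic rings of naphthalen-1-yl for the single ring of 2,6-dimethylphenyl gives a 2.0-fold lower number from compound 3 to compound 4 (0.29 log units; within the scatter) and so produces no clear change. Comparing this group with the two other groups tested on the amide-type nitrogen gives a 1.2-fold higher number from compound 2 to compound 4 (0.06 log units; within the scatter) and a 1.2-fold lower number from compound 1 to compound 4 (0.07 log units; within the scatter) as well, so compound 4 cannot be told apart from any earlier compound, even though compound 2 and compound 3 do stand apart from each other. Nothing measured here bears on the reason for this result.

All four groups on this nitrogen are aromatic carbon rings, so the compounds shown leave open whether a plain butyl chain there, or a phenyl ring carrying an amine or a carboxylic acid, would keep the number in the same range. Because only this one position varies, they also leave open how the number would respond to a change elsewhere on the shared core, such as a longer chain in place of the ethyl group.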